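The compounds below may be only part of what the source reports. "The series", "measured", "known", "first", "only" and "open" are said of these compounds alone.

Measured so far:
compound 1 `Cc1[nH]n(-c2cccc(C(F)(F)F)c2)c(=O)c1/N=N/c1c(O)cc(S(=O)(=O)O)c2ccccc12` — 62%
compound 2 `Cc1[nH]n(-c2ccc(I)cc2)c(=O)c1/N=N/c1c(O)cc(S(=O)(=O)O)c2ccccc12` — 81%

In an assay on BaF3 cells with thrombopoietin receptor (Homo sapiens) as the target, read by a luciferase reporter (a lower number here means a smaller maximal response, a higher number a larger maximal response), compound 2 stands highest of the two numbers; the nearest is compound 1, reached by the step of a number 19 percentage points higher from compound 1 to compound 2 (beyond the scatter). Compound 3 `Cc1ccc(-n2[nH]c(C)c(/N=N/c3c(O)cc(S(=O)(=O)O)c4ccccc34)c2=O)cc1C` differs from compound 2 by 3,4-dimethylphenyl in place of 4-iodophenyl on an aromatic nitrogen. Among the compounds with values here, the only step bearing on this is the one from compound 1 to compound 2, also an exchange of the aryl group on the aromatic nitrogen, which moved the maximal response beyond the scatter. Its direction for a third aryl group is not fixed by the data, so a step of modest size either way, or none beyond the scatter, is expected. For compound 3 the expected step is a number 9 percentage points lower from compound 2 to compound 3 (within the scatter). Compound 3 is estimated at 72%, with a range from 55% to 90%.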

Compound 3, largest response reached (reported as efficacy), in percent of the reference or control that the assay uses: 100%
Compound 3: the middle estimate sits 28 percentage points below what was measured, and the stated range ends below it.
By their numbers in this assay, from the lowest: compound 1; then compound 2; then compound 3.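

In this assay the aryl group on the aromatic nitrogen again sets the maximal response: there is a number 19 percentage points higher from compound 2 to compound 3 (beyond the scatter), and a number 38 percentage points higher from compound 1 to compound 3 (beyond the scatter). With the rest of the molecule unchanged, this position alone now spans a large step, and 3,4-dimethylphenyl stands above both 4-iodophenyl and 3-(trifluoromethyl)phenyl. Nothing available explains this order. Open, going by these compounds, is whether 3-methylphenyl or 4-methylphenyl alone would carry the step, and how an aminophenyl or carboxyphenyl group would behave at this nitrogen.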